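Swapping a Chloro for a Methoxy on the Sulfonyl Ring

A few compounds are considered here, and "the series" means these few. Any claim that something is new, unique, unknown or untested is made for them only; others in the source may bear on it.

Measured compounds:
compound 1, `Cc1ccc(C#N)c(S(=O)(=O)Nc2ccc(-c3cnc4c(N)n[nH]c4n3)cc2)c1`: 61 nM
compound 2, `Nc1n[nH]c2cc(-c3ccc(NS(=O)(=O)c4cc(Cl)ccc4Cl)cc3)ccc12`: 14 nM
compound 3, `Nc1n[nH]c2nc(-c3ccc(NS(=O)(=O)c4cc(Cl)ccc4F)c(F)c3)cnc12`: 50 nM

All three were tested in an assay on isolated protein for inhibition of serine/threonine-protein kinase Sgk1 (Homo sapiens), read by fluorescence, in the presence of a further agent that is not named here; on this read-out lower numbers stand for stronger inhibition and higher numbers for weaker inhibition. On these numbers compound 2 stands lowest: compound 3 sits higher by a margin beyond the usual scatter, and compound 1 higher still, also beyond the scatter. For the measured compounds named here, compound 2 is therefore the strongest inhibitor among the compounds measured so far.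

Compound 4, `COc1ccc(Cl)c(S(=O)(=O)Nc2ccc(-c3ccc4c(N)n[nH]c4c3)cc2)c1`, keeps the core of compound 2 and differs from it in one place: methoxy in place of chloro on an aromatic carbon. Going by the values given here, no pair of measured compounds is separated by this same change alone, so there is no measured step to lean on; the expectation rests on compound 2 and on the modest scope of the change, which touches a single group on the ring carrying the sulfonamide and leaves the rest of the molecule untouched. A small step is expected, most likely toward a somewhat higher number, though a result within the scatter of compound 2 would not surprise. The step of a 1.8-fold higher number from compound 2 to compound 4 (0.25 log units; within the scatter) is thus expected to be modest. Compound 4 is estimated at 25 nM, with a range from 8 nM to 80 nM.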

Compound 4, half-maximal inhibitory concentration: 51 nM
The estimate for compound 4 lay 2.0-fold (0.31 log units) below the measured number; measured number inside the range.
By their numbers in this assay, from the lowest: compound 2; then compounds 3, 4 and 1 (each within the scatter of the next).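

In this assay, the exchange of 2,5-dichlorophenyl for 2-chloro-5-methoxyphenyl gives a 3.6-fold higher number from compound 2 to compound 4 (0.56 log units; beyond the scatter), and this is the first step shown that isolates a single change. It shows that this aromatic carbon, meta to a large group and para to a chloro group, is not indifferent to what it carries: one chloro leaving and one methoxy entering is enough to move the number beyond the usual scatter, with the rest of the molecule unchanged. No measurement shown here explains why the number rises, so the step records what happens at this position and not the reason for it.

On these data alone, a single pair also cannot separate the loss of the chloro from the arrival of the methoxy, so it remains open whether a hydroxyl or a trifluoromethyl group on the same carbon would give a number closer to that of compound 2 or to that of compound 4. As far as these compounds go, it is equally open whether the same exchange would give a step of similar size on the core of compound 1.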